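A few compounds are considered here, and "the series" means these few. Any claim that something is new, unique, unknown or untested is made for them only; others in the source may bear on it.

Measured compounds:
Compound 1, `Cc1cc(N2CC[C@@H](C)[C@@H](N(C)c3ncnc4[nH]ccc34)C2)n2ncnc2n1`, in a functional assay on BGC-823 cells (Homo sapiens) for inhibition, read by MTT assay, with a stated time of 72 h; on this read-out lower numbers stand for stronger inhibition and higher numbers for weaker inhibition: 67400 nM
Compound 2, `Cc1cc(N2CC[C@@H](C)[C@@H](N(C)c3ncnc4[nH]ccc34)C2)n2nc(SCc3ccc(C(F)(F)F)cc3)nc2n1`, in this assay: 23300 nM

Compound 1 gives the highest number of the two. The nearest is compound 2, reached by a 2.9-fold lower number from compound 1 to compound 2 (0.46 log units; beyond the scatter) through (4-(trifluoromethyl)benzyl)sulfanyl in place of hydrogen on an aromatic carbon.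

Compound 3, `C[C@@H]1CCN(c2cc(-c3ccccc3)nc3ncnn23)C[C@@H]1N(C)c1ncnc2[nH]ccc12`, has not yet been measured. It differs from compound 1 as follows: phenyl in place of methyl on an aromatic carbon The phenyl sits on an aromatic carbon of a six-membered aromatic ring with 2 nitrogen, part of a fused system of two rings, next to the ring nitrogen and para to a fused ring.

Going by the values given here, no measured step exchanges a methyl for a phenyl at this place. Among the compounds with values here, the only step available, a 2.9-fold lower number from compound 1 to compound 2 (0.46 log units; beyond the scatter), concerns a different position on the shared core and shows that enlarging the molecule with a larger aromatic group there gave a modest lower number. Taken loosely as a guide, a step of similar modest size is expected for compound 3, again toward a lower number, though the direction is uncertain. Compound 3 is therefore estimated to give 30000 nM in this assay, within the range 8000 nM to 130000 nM, corresponding to a 2.2-fold lower number from compound 1 to compound 3 (0.35 log units; beyond the scatter).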

Compound 3, half-maximal inhibitory concentration: > 100000 nM
Compound 3 ended at the assay's limit; the forecaster's own chance of this, stated with the estimate: 15%; at least 3.3-fold (0.52 log units) between middle value and limit.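

In this assay compound 3 gives > 100000 nM as a limit of the assay and not as a number: the limit of > 100000 nM in this assay, at which 1 of the 3 values shown sits. Phenyl in place of methyl at this aromatic carbon therefore brings no measurable lowering of the number, and the step reads an at least 1.4-fold higher number from compound 1 to compound 3 (0.17 log units; that floor lies within the scatter) as far as it can be read, so compound 3 cannot be placed clearly above compound 1. The earlier compounds shown here showed only a lower number with a larger group at another place on the shared core, and this result shows that such a lowering does not follow from every larger aromatic group at every place on that core.

As far as these compounds go, the true value of compound 3 remains unknown, and so does the size of any change that phenyl brings here. Also open, from the compounds shown here alone, is how this aromatic carbon would respond to an amine, a methoxy group or a longer alkyl chain in place of the methyl, and whether any group there could lower the number at all.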